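Adding a trifluoromethyl group: tolerability expected to stay high

This account rests on a few compounds, and the source may have more. Where it says the series, first, only, none or still open, it means among the compounds named here.

Of the compounds shown here, two have so far been tested in an ADME assay on HuH6 cells (Homo sapiens) for cytotoxicity; a higher number here means that more compound is tolerated, a lower number that less compound is tolerated. Compound 1, `NC(=O)c1nc(C#Cc2ccc(C(F)(F)F)cc2)n([C@@H]2O[C@H](CO)[C@@H](O)[C@H]2O)n1`, gives > 120000 nM, which is a limit of the assay rather than a measured number. Compound 2, `NC(=O)c1nc(C#Cc2ccccc2)n(COCCO)n1`, gives > 170000 nM, again a limit and not a number. So compound 2 stands only at a limit, and the one other value shown is a limit as well: one value sits at the limit of > 120000 nM in this assay, at which 1 of the 2 values shown sits, and one at the limit of > 170000 nM in this assay, at which 1 of the 2 values shown sits, and neither compound has a measured cytotoxic concentration. Going by the values given here, because the two structures differ in more than one place, the two values show only that both compounds were tolerated up to the highest concentration tested.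

Compound 3, `NC(=O)c1nc(C#Cc2ccc(C(F)(F)F)cc2)n(COCCO)n1`, is compound 2 with trifluoromethyl in place of hydrogen on an aromatic carbon. Among the compounds with values here, no step between measured compounds is available to guide this change. Compound 3 is expected to be tolerated about as well as compound 2, since compound 2 gives > 170000 nM; the expected step is a number no higher from compound 2 to compound 3 (the limit leaves the size open), that is, none beyond the scatter. The estimate for compound 3 is 170000 nM, within a range from 100000 nM to 300000 nM, most likely reported again only as a limit.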

Compound 3, half-maximal cytotoxic concentration: 87500 nM
The estimate for compound 3 lay 1.9-fold (0.29 log units) above the measured number; measured number below the stated range.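

In this assay, compound 3 is the first compound shown with a measured number rather than a limit, which gives both of its neighbours a step that can be read, though only in part. Trifluoromethyl in place of hydrogen on an aromatic carbon, para to a large group, gives an at least 1.9-fold lower number from compound 2 to compound 3 (0.28 log units; that floor lies within the scatter), and (2-hydroxyethoxy)methyl in place of 3,4-dihydroxy-5-(hydroxymethyl)oxolan-2-yl on an aromatic nitrogen gives an at least 1.3-fold lower number from compound 1 to compound 3 (0.13 log units; that floor lies within the scatter). Both steps are floors only, because each starts from a compound that stands at a limit: the limit of > 120000 nM in this assay, at which 1 of the 3 values shown sits; (the limit of > 170000 nM in this assay, at which 1 of the 3 values shown sits).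

Going by these compounds, whether either change truly moves the number beyond the scatter stays open, as the real size of each step could be anywhere from its floor upward. Also open, on these data alone, is how a chlorine atom, a methoxy group or an amine in the same place on the aromatic ring would compare with trifluoromethyl, and how a longer chain on the aromatic nitrogen would compare with (2-hydroxyethoxy)methyl.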